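Tetrazole to carbinol swap in a trifluoromethyl hydroxyamide series

The compounds below may be only part of what the source reports. "The series", "measured", "known", "first", "only" and "open" are said of these compounds alone.

Among the measured compounds shown here, compound 1 `Cn1nnnc1-c1ccc(NC(=O)C(C)(O)C(F)(F)F)cc1` is the only member of the set with a number in an assay on a protein complex (Cavia porcellus) with sulfonylurea receptors; K-ATP channels (Homo sapiens) as the target (a higher number here means a weaker inhibitor, a lower number a stronger inhibitor), where compound 1 gives 30900 nM. Compound 2 `CC(O)(C(=O)Nc1ccc(/C(=N\O)c2ccccc2)cc1)C(F)(F)F` returns only a limit of the assay in this assay, > 30000 nM. For the measured compounds named here, one of the two values shown therefore sits at the limit of > 30000 nM in this assay, at which 1 of the 2 values shown sits, so no measured step between compounds can be drawn; compound 1 and compound 2 show only that one has a number and the other a limit. Compound 3 `CC(O)(C(=O)Nc1ccc([C@@H](O)c2ccccc2)cc1)C(F)(F)F` is not yet measured in this assay. It differs from compound 1 in one place: hydroxy(phenyl)methyl in place of 1-methyl-1H-tetrazol-5-yl on an aromatic carbon. Going by the values given here, with no measured step, the size of this change is open; compound 1 already sits close to the limit, and the related compound 2 reaches only the limit, so no gain beyond the scatter is expected, and a fair chance remains that compound 3 also returns a limit rather than a number. The step from compound 1 to compound 3 is expected to be small, a 1.1-fold higher number from compound 1 to compound 3 (0.05 log units; within the scatter). Compound 3 is estimated at 35000 nM, with a range from 15000 nM to 100000 nM.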

Compound 3, half-maximal inhibitory concentration: > 30000 nM
Compound 3: a limit, no number; the forecaster's own chance of this, stated with the estimate: 55%; the middle value lies beyond the limit too.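

Compound 3 returns > 30000 nM in this assay, a limit of the assay and not a number. Among the compounds shown here, no step from compound 1 to compound 3 can therefore be read. The compounds shown leave open how far hydroxy(phenyl)methyl in place of 1-methyl-1H-tetrazol-5-yl moves the read-out, with most of the set sitting at one value: the limit of > 30000 nM in this assay, at which 2 of the 3 values shown sit.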